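This account rests on a few compounds, and the source may have more. Where it says the series, first, only, none or still open, it means among the compounds named here.

Two members of the shared core have been measured so far. Compound 1 `CC(=O)Nc1ccc(OCc2nnc(SCC(=O)Nc3ccc([N+](=O)[O-])cc3)n2Cc2ccccc2)cc1` gives 105 ug/mL in a toxicity assay on MT4 cells (Homo sapiens) for cytotoxicity, read by MTT assay, with a stated time of 5 days; a higher number here means that more compound is tolerated, a lower number that less compound is tolerated. Compound 2 `O=C(CSc1nnc(COc2ccc3ccccc3c2)n1Cc1ccccc1)Nc1ccc(Cl)cc1` stands only at a limit of this assay, >= 4.93 ug/mL, not at a number; this is the limit of >= 4.93 ug/mL in this assay, at which 1 of the 2 values shown sits. Compound 3 `O=C(CSc1nnc(COc2ccc3ccccc3c2)n1Cc1ccccc1)Nc1ccc([N+](=O)[O-])cc1` is compound 2 with nitro in place of chloro on an aromatic carbon. Among the compounds with values here, no measured pair isolates this change; compound 1 carries the same nitro group on a differently substituted core. The step from compound 2 to compound 3 in this assay is expected to be modest, a step that the limit leaves unreadable from compound 2 to compound 3, with the direction open. Compound 3 is estimated at 40 ug/mL, between 8 ug/mL and 150 ug/mL.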

Compound 3, half-maximal cytotoxic concentration: >= 116 ug/mL
Compound 3 gave a limit, no number; the forecaster's own chance of this, stated with the estimate: 35%; middle value at least 2.9-fold (0.46 log units) from the limit.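

In this assay compound 3 stands at a limit (>= 116 ug/mL), not at a number. Compound 2 also stands only at a limit (>= 4.93 ug/mL), so nitro in place of chloro, para to a large group, cannot be read. Within the data shown here, the one readable step, naphthalen-2-yl in place of 4-acetamidophenyl (an at least 1.1-fold higher number from compound 1 to compound 3 (0.04 log units; that floor lies within the scatter)), gives only a floor and establishes no shift.

Going by these compounds, the size and direction of the chloro to nitro change remain open. So does the outcome with an amine or a carboxylic acid at this position.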